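Compound 2 to compound 4: aryl swap, solubility expected flat

The source may report more compounds than this note shows. Statements on the series, on what has been measured and on what is new or still open speak of the compounds shown alone.

Values in a physicochemical assay for solubility, in phosphate buffer, measured as kinetic solubility, at pH 7.4; a lower number here means a less soluble compound, a higher number a more soluble compound:
compound 1 `Cc1ccccc1-c1nc(CN2CCC(C(=O)NCCCN3CCC(C)CC3)CC2)c(C)o1`: > 67 ug/mL (a limit)
compound 2 `Cc1oc(-c2c(Br)cccc2Br)nc1CN1CCC(C(=O)NCCCN2C[C@H](C)C[C@H](C)C2)CC1`: 62.4 ug/mL (a number)
compound 3 `Cc1cccc(Cl)c1-c1nc(CN2CCC(C(=O)NCCCN3CCC(C)(C)CC3)CC2)c(C)o1`: > 74 ug/mL (a limit)

Among the measured compounds shown here, compound 2 holds the only actual number in this set, since the other two entries are limits, so it cannot be ranked against them. Compound 4 `Cc1ccc(-c2nc(CN3CCC(C(=O)NCCCN4C[C@H](C)C[C@H](C)C4)CC3)c(C)o2)cc1` carries 4-methylphenyl in place of 2,6-dibromophenyl on an aromatic carbon. For the measured compounds named here, no measured step isolates this change, so the expectation starts from compound 2 at 62.4 ug/mL and assumes no shift beyond the usual scatter, in either direction. The expected change is a 1.0-fold higher number from compound 2 to compound 4 (0.02 log units; within the scatter). For compound 4 the estimated solubility is 65 ug/mL with an expected range from 38 ug/mL to 75 ug/mL.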

Compound 4, solubility: > 69 ug/mL
Compound 4: a limit, no number (the forecaster's own chance of this, stated with the estimate: 55%); middle value at least 1.0-fold (0.02 log units) away from the limit.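

In this assay, 4-methylphenyl in place of 2,6-dibromophenyl on an aromatic carbon gives an at least 1.1-fold higher number from compound 2 to compound 4 (0.04 log units; that floor lies within the scatter). The reading for compound 4 is a limit and not a number: the limit of > 69 ug/mL in this assay, at which 1 of the 4 values shown sits. As far as these compounds go, both bromines can therefore leave this position with no fall in the reading, but the size of any rise stays unknown.

Still open, from the compounds shown here alone, is how a pyridyl or a 4-methoxyphenyl group at this position would read in this assay. Also open, going by these compounds, is whether any group here brings the reading down beyond the scatter.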